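Permeability and the aryl linker in this series

The source may hold more compounds than are shown below. What is called first, only, known or untested is meant among the compounds shown, and "the series" means these compounds.

Compound 3 `COc1cccc(CNCCCNc2ccnc3cc(Oc4cccc(N(C)C)c4)ccc23)c1O` gives 317 10^-6 cm/s in an ADME assay for permeability, using PAMPA, with a stated time of 30 min, at pH 7.4; on this read-out lower numbers stand for lower permeability and higher numbers for higher permeability; this stands level with compound 1 `COc1cccc(CNCCCNc2ccnc3cc(Oc4ccccc4)ccc23)c1O`, which gives 317 10^-6 cm/s, the two together being the highest of the three numbers, whereas compound 2 `COc1cccc(CNCCCNc2ccnc3cc(Cc4cc(C)cc(C)c4)ccc23)c1O` gives 23 10^-6 cm/s. Toward compound 4 `COc1cccc(CNCCCNc2ccnc3cc(Cc4ccccc4)ccc23)c1O` the change is benzyl in place of 3-(dimethylamino)phenoxy on an aromatic carbon. Among the measured compounds shown here, two measured steps bear on this: a 14-fold lower number from compound 1 to compound 2 (1.14 log units; beyond the scatter) and a 14-fold higher number from compound 2 to compound 3 (1.14 log units; beyond the scatter), both large, while no change at the digits printed from compound 1 to compound 3 (within the scatter) shows that the dimethylamino group on its own left the number unchanged. Compound 4 carries a benzyl group, as compound 2 carries 3,5-dimethylbenzyl, so a large downward step is expected because a 14-fold lower number from compound 1 to compound 2 (1.14 log units; beyond the scatter). For compound 4 the expected step is an 11-fold lower number from compound 3 to compound 4 (1.02 log units; beyond the scatter). Compound 4 is therefore estimated at 30 10^-6 cm/s, in the range 10 10^-6 cm/s to 100 10^-6 cm/s.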

Compound 4, apparent permeability: 23 10^-6 cm/s
Beside the measured number, compound 4's estimate is 1.3-fold (0.12 log units) above it; measured number inside the range.
By their numbers in this assay, from the lowest: compounds 2 and 4 (each within the scatter of the next); then compounds 1 and 3 (each within the scatter of the next).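

The benzyl group of compound 4 gives the same picture in this assay as the 3,5-dimethylbenzyl group of compound 2: a 14-fold lower number from compound 3 to compound 4 (1.14 log units; beyond the scatter) and a 14-fold lower number from compound 1 to compound 4 (1.14 log units; beyond the scatter), while phenyl in place of 3,5-dimethylphenyl gives no change at the digits printed from compound 2 to compound 4 (within the scatter). Among these four compounds the numbers therefore divide by group, with the phenoxy types high and the benzyl types low, and no compound goes against this. Nothing available explains this split. As far as these compounds go, it remains open where a thioether or an amine in place of the phenoxy oxygen would fall.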